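Bromo to phenyl on the shared core, cytotoxicity read-out

This account rests on a few compounds, and the source may have more. Where it says the series, first, only, none or still open, it means among the compounds named here.

Compound 1 `Brc1ccc(C(c2ccccc2)N2CCN(c3ncnc4c3cnn4-c3ccccc3)CC2)cc1`: > 25000 nM
Compound 2 `Cc1ccsc1C(c1ccccc1Br)N1CCN(c2ncnc3c2cnn3-c2ccccc2)CC1`: > 25000 nM

In a functional assay on cells (Rhabdomyosarcoma cell, Homo sapiens) for cytotoxicity (a higher number here means a weaker inhibitor, a lower number a stronger inhibitor), compound 1 gives only a limit of the assay, > 25000 nM, and not a number. Compound 2 likewise gives only a limit, > 25000 nM. Both values sit at the same limit, so nothing on the numbers shown places compound 1 above or below compound 2; compound 1 stands with compound 2 at the edge of what this assay reports (the limit of > 25000 nM in this assay, at which 2 of the 2 values shown sit).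

Compound 3 `c1ccc(-c2ccc(C(c3ccccc3)N3CCN(c4ncnc5c4cnn5-c4ccccc4)CC3)cc2)cc1` differs from compound 1 in one place: phenyl in place of bromo on an aromatic carbon. Among the compounds with values here, no step between two measured compounds is given for this change, so no measured size can be drawn on. Because both measured values sit at the limit (the limit of > 25000 nM in this assay, at which 2 of the 2 values shown sit), a step beyond the scatter in either direction cannot be read from them. Compound 3 is therefore expected to give 25000 nM, within 8000 nM to 60000 nM, most likely again only as a limit; the expected step from compound 1 to compound 3 is a number no higher from compound 1 to compound 3 (the limit leaves the size open).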

Compound 3, half-maximal inhibitory concentration: > 25000 nM
Compound 3 gave a limit, no number (the forecaster's own chance of this, stated with the estimate: 75%); the middle value lies on the limit itself.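

Compound 1 and compound 3 both give only a limit and not a number, so no step for phenyl in place of bromo can be read between them in this assay: the limit of > 25000 nM in this assay, at which 3 of the 3 values shown sit.

The compounds shown leave open how strong any of them actually is, and whether this change alters cytotoxicity at all.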